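The compounds below may be only part of what the source reports. "The series", "measured", "known", "first", "only" and "open" are said of these compounds alone.

Working notes on the series. In a functional assay on HL-60 cells (Homo sapiens) for cytotoxicity, read by WST assay, with a stated time of 48 h (on this read-out higher numbers stand for an effect only at larger amounts of compound and lower numbers for an effect already at smaller amounts), compound 1 `O=C1OC[C@H](Cc2ccccc2)[C@H]1Cc1ccccc1` gives 77000 nM, and compound 2 `O=C1OC[C@H](Cc2ccccc2)[C@H]1Cc1ccccc1O` gives 83000 nM. Compound 3 `O=C1OC[C@H](Cc2ccccc2)[C@H]1Cc1cccc(O)c1` gives only a limit, > 100000 nM, and not a number.

The next compound to be read is compound 4 `O=C1OC[C@H](Cc2ccccc2)[C@H]1Cc1cccc(OC(F)(F)F)c1`. It replaces hydroxy with trifluoromethoxy, that is, trifluoromethyl in place of hydrogen on an oxygen on an aromatic ring.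

Going by the values given here, no measured step covers this group, so the nearest guides are the changes on the same aromatic ring. These are a 1.1-fold higher number from compound 1 to compound 2 (0.03 log units; within the scatter), an at least 1.2-fold higher number from compound 1 to compound 3 (0.11 log units; that floor lies within the scatter) and an at least 1.2-fold higher number from compound 2 to compound 3 (0.08 log units; that floor lies within the scatter). All three are small, and two of them rest on a floor only, so they give little reason to expect a large move in this assay.

The expected change is an at least 1.4-fold lower number from compound 3 to compound 4 (0.15 log units; that floor lies within the scatter), a modest step towards lower numbers, with no large shift anticipated. The estimate for compound 4 is 70000 nM, with an expected range of 30000 nM to 100000 nM.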

Compound 4, half-maximal effective concentration: 34000 nM
Beside the measured number, compound 4's estimate is 2.1-fold (0.31 log units) above it; measured number inside the range.
By their numbers in this assay, from the lowest: compound 4; then compounds 1 and 2 (each within the scatter of the next). At a limit, above all of these: compound 3.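

In this assay, going by these compounds alone, trifluoromethoxy on the aromatic ring gives the first step that is beyond the scatter, a 2.3-fold lower number from compound 1 to compound 4 (0.36 log units; beyond the scatter), whereas the hydroxy steps from compound 1 showed nothing beyond it. At the same place, trifluoromethyl in place of hydrogen on the oxygen gives an at least 2.9-fold lower number from compound 3 to compound 4 (0.46 log units; beyond the scatter), so this oxygen substituent changes the read-out where the free hydroxy did not. The size of that second step is a floor only, since compound 3 stands at a limit and not at a number: the limit of > 100000 nM in this assay, at which 1 of the 4 values shown sits.

From the compounds shown here alone, it remains open whether methoxy, chlorine or an amine at this place would give a similar step. Also open, going by these compounds, is whether trifluoromethoxy would do the same on the other aromatic ring of the core.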